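Methylating the hydroxyl oxygen of compound 2: expected cytotoxicity

The source may report more compounds than this note shows. Statements on the series, on what has been measured and on what is new or still open speak of the compounds shown alone.

Compound 2 `CCc1cccc2c(OC)c(-c3occ(C)c3CO)ccc12` gives 7.1 ug/mL in a functional assay on KB cells (Homo sapiens) for cytotoxicity, read by MTT assay, with a stated time of 72 h (a higher number here means that more compound is needed for the effect, a lower number that less compound is needed), the only plain number among the two results shown. Compound 1 `CCc1cccc2c(OC)c(-c3occ(C)c3C(=O)NC)ccc12` is recorded only as a limit, > 10 ug/mL in this assay. Going by the values given here, the sole measured step is an at least 1.4-fold lower number from compound 1 to compound 2 (0.14 log units; that floor lies within the scatter), and its size is itself bounded by the limit of > 10 ug/mL in this assay, at which 1 of the 2 values shown sits. Compound 3 `CCc1cccc2c(OC)c(-c3occ(C)c3COC)ccc12` differs from compound 2 by methyl in place of hydrogen on an oxygen on a saturated carbon. That measured step concerns a different group, so it offers little direct guidance here, and a step no larger than the scatter is expected, as a 1.0-fold lower number from compound 2 to compound 3 (0.01 log units; within the scatter). Compound 3 is therefore estimated at 7 ug/mL, between 3 ug/mL and 15 ug/mL.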

Compound 3, concentration for half-maximal effect: > 10 ug/mL
Compound 3 ended at the assay's limit; the forecaster's own chance of this, stated with the estimate: 30%; middle value at least 1.4-fold (0.15 log units) away from the limit.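

Hydroxy to methoxy is the first change shown on the hydroxymethyl group itself, and it gives an at least 1.4-fold higher number from compound 2 to compound 3 (0.14 log units; that floor lies within the scatter). Going by these compounds alone, compound 2, at 7.1 ug/mL, remains the only compound with a plain number, so no series of values can yet be read at this position. The true size of this step is unknown, and the step between compound 1 and compound 3 cannot be read, because the values end at a limit: the limit of > 10 ug/mL in this assay, at which 2 of the 3 values shown sit.

On these data alone, whether the free hydroxy group matters at all remains open. So does whether an amine, a carboxylic acid or an ethoxymethyl group in place of hydroxymethyl would give a plain number in this assay.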